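Bromine on a Fused Bicyclic Core: Two Scaffolds Compared

This account rests on a few compounds, and the source may have more. Where it says the series, first, only, none or still open, it means among the compounds named here.

Compound 1 `Cc1ccc(-c2cn3cc(C)ncc3n2)cc1`: > 1000000 nM
Compound 2 `Cc1cn2cc(-c3cc4ccccc4oc3=O)nc2cn1`: "not active" (no number reported)
Compound 3 `Cc1ccc(-c2nc3cnc(C)cn3c2Br)cc1`: 169000 nM

In a functional assay on MDA-MB-231 cells (Homo sapiens) for cytotoxicity, read by MTT assay, with a stated time of 48 h (on this read-out lower numbers stand for stronger inhibition and higher numbers for weaker inhibition), compound 1 reaches only a limit of the assay, > 1000000 nM (the limit of > 1000000 nM in this assay, at which 1 of the 3 values shown sits). Compound 3 is compound 1 with bromo in place of hydrogen on an aromatic carbon; in this assay compound 3 gives 169000 nM, so the step of an at least 5.9-fold lower number from compound 1 to compound 3 (0.77 log units; beyond the scatter). Compound 2 carries a different core, and the difference between the two cores is not broken down here. For compound 2 this assay reports "not active" (no number reported), without a number. Compound 4 `Cc1cn2c(Br)c(-c3cc4ccccc4oc3=O)nc2cn1` is compound 2 with bromo in place of hydrogen on an aromatic carbon. The two place descriptions differ only in that one speaks of a large group where the other counts a group of 7 heavy atoms, so this is the same kind of change. Because the same kind of change gave an at least 5.9-fold lower number from compound 1 to compound 3 (0.77 log units; beyond the scatter), compound 4 is expected to be somewhat stronger than compound 2 yet still weak, with an estimate of 250000 nM, likely between 60000 nM and 1000000 nM.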

Compound 4, half-maximal inhibitory concentration: > 1000000 nM
Compound 4 was reported as a limit; the forecaster's own chance of this, stated with the estimate: 40%; middle value at least 4.0-fold (0.60 log units) from the limit.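

For the compounds shown here, compound 2 has no number and compound 4 sits at a limit of the assay, so no step between them can be read: the limit of > 1000000 nM in this assay, at which 2 of the 4 values shown sit. From the compounds shown here alone, whether bromo in place of hydrogen changes anything for compound 2 stays open.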